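Swapping the heptyl of compound 2 for hydroxy

A few compounds are considered here, and "the series" means these few. Any claim that something is new, unique, unknown or untested is made for them only; others in the source may bear on it.

Two compounds measured in a functional assay on HCT-116 cells (Homo sapiens) for antiproliferative activity, read by MTT assay, with a stated time of 48 h; on this read-out higher numbers stand for weaker inhibition and lower numbers for stronger inhibition
Compound 1 `CC(CCO)n1cnc2c(Cl)ncnc21` gives > 50000 nM (a limit, not a number)
Compound 2 `CCCCCCCCC(CCO)n1cnc2c(Cl)ncnc21` gives 1650 nM

Among the compounds with values here, compound 2 holds the only actual number on this read-out, 1650 nM (half-maximal inhibitory concentration). Compound 1 sits at the limit of > 50000 nM in this assay, at which 1 of the 2 values shown sits, and so has a limit only.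

Compound 3 `OCCC(CO)n1cnc2c(Cl)ncnc21` has not yet been measured. Relative to compound 2 it carries hydroxy in place of heptyl on a saturated chain carbon, two bonds along the chain from an aromatic nitrogen.

Within the data shown here, one measured step bears on this change, and it is large and beyond the scatter (an at least 30-fold lower number from compound 1 to compound 2 (1.48 log units; beyond the scatter)). That step added the heptyl at this same place, and compound 3 gives it up again. A large step in the opposite direction, to a higher number in this assay, is therefore expected. The expected move is a 30-fold higher number from compound 2 to compound 3 (1.48 log units; beyond the scatter), and the assay may well report only a limit. For compound 3 the estimated value is 50000 nM, with an expected range from 20000 nM to 120000 nM (an estimate, not a measurement).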

Compound 3, half-maximal inhibitory concentration: > 50000 nM
Compound 3 ended at the assay's limit (the forecaster's own chance of this, stated with the estimate: 70%); the middle value lies on the limit itself.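

In this assay, the hydroxy of compound 3 does not stand in for the heptyl at this place, on a saturated chain carbon, two bonds along the chain from an aromatic nitrogen: the change gives an at least 30-fold higher number from compound 2 to compound 3 (1.48 log units; beyond the scatter). The earlier compounds had shown only that hydrogen at this place gave a limit where heptyl gave a number; now a second, different replacement of the heptyl also ends at a limit, so among the three compounds only the one carrying heptyl has a measurable value. Hydrogen and hydroxy cannot be ranked against each other, and the step between compound 1 and compound 3 cannot be read, since both stand at the same limit: the limit of > 50000 nM in this assay, at which 2 of the 3 values shown sit.

From the compounds shown here alone, what stays open is how much of the heptyl matters, that is, whether a shorter chain such as propyl or a longer chain such as decyl would give a number in this assay at all. Also open, going by these compounds, is how a phenyl ring or an amine at this place would read against the heptyl of compound 2.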